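Compound 4 and the Limit of the Assay

The source may hold more compounds than are shown below. What is called first, only, known or untested is meant among the compounds shown, and "the series" means these compounds.

In a functional assay on HCT-116 cells (Homo sapiens) for inhibition, read by CCK-8 assay, with a stated time of 48 h (a higher number here means a weaker inhibitor, a lower number a stronger inhibitor), compound 1 `COc1ccc(CN(C(=O)CSC(=S)N2CCN(C)CC2)c2cc(OC)c(OC)c(OC)c2)cc1` gives 2640 nM and compound 2 `COc1ccc(CN(C(=O)CSC(=S)N2CCN(C(C)=O)CC2)c2cc(OC)c(OC)c(OC)c2)cc1` gives 1370 nM. Compound 3 `COc1cc(N(Cc2ccc(C)cc2)C(=O)CSC(=S)N2CCN(C(=O)OC(C)(C)C)CC2)cc(OC)c1OC` stands at > 20000 nM, which is a limit of the assay and not a number. Within this small series, compound 3 alone marks (the limit of > 20000 nM in this assay, at which 1 of the 3 values shown sits).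

Compound 4 `COc1ccc(CN(C(=O)CSC(=S)N2CCN(C(=O)OC(C)(C)C)CC2)c2cc(OC)c(OC)c(OC)c2)cc1[N+](=O)[O-]` differs from compound 3 in one place: 4-methoxy-3-nitrophenyl in place of 4-methylphenyl on a saturated chain carbon bound to an amide-type nitrogen. In words, 4-methoxy-3-nitrophenyl stands in place of 4-methylphenyl on a saturated chain carbon bound to an amide-type nitrogen.

Going by the values given here, the only measured step, a 1.9-fold lower number from compound 1 to compound 2 (0.28 log units; within the scatter), comes from acetyl in place of methyl on an amine nitrogen in a ring. That is a different place in the molecule, so it offers no size for the present change. The expectation therefore rests mainly on compound 3, whose > 20000 nM is a limit. Compound 4 keeps everything outside the exchanged group, so only a modest move in this assay, toward a lower number, is expected, and a second limit reading would be no surprise. The expected change is an at least 1.3-fold lower number from compound 3 to compound 4 (0.12 log units; that floor lies within the scatter). Compound 4 is estimated at 15000 nM, with an expected range of 5000 nM to 30000 nM.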

Compound 4, half-maximal inhibitory concentration: 980 nM
Beside the measured number, compound 4's estimate is 15-fold (1.18 log units) above it, outside the stated range (below it).
By their numbers in this assay, from the lowest: compounds 4, 2 and 1 (each within the scatter of the next, the first and the last beyond it). At a limit, above all of these: compound 3.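

In this assay, 4-methoxy-3-nitrophenyl in place of 4-methylphenyl on a saturated chain carbon bound to an amide-type nitrogen gives an at least 20-fold lower number from compound 3 to compound 4 (1.30 log units; beyond the scatter), so this place in the molecule, untouched by the earlier step between compound 1 and compound 2, can move the number well beyond the scatter. Compound 3 stands at a limit of the assay and not at a number, so the size of this step is only a floor: the limit of > 20000 nM in this assay, at which 1 of the 4 values shown sits. The tert-butoxycarbonyl group shared by compound 3 and compound 4 also does not by itself keep a compound's number high, since compound 4 carries it and gives 980 nM.

From the compounds shown here alone, whether the methoxy group, the nitro group or the two together carry this step remains open, as the entering group brings them in as one exchange. Also open, going by these compounds, are how an amine or a carboxylic acid in place of the nitro group would read in this assay, and whether the same exchange would move the number as far with the methyl of compound 1 or the acetyl of compound 2 on the ring nitrogen.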